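From 1-carboxypropyl to 1-carboxyethyl: Expected Clearance of Compound 4

The source may hold more compounds than are shown below. What is called first, only, known or untested is meant among the compounds shown, and "the series" means these compounds.

In an ADME assay on the whole organism (Mus musculus, strain CD1) for pharmacokinetics, read by LC-MS, with a stated time of 24 h, at a dose of 1 mg/kg by the intravenous route (on this read-out lower numbers stand for slow clearance and higher numbers for fast clearance), compound 3 (`CCC(C(=O)O)c1nn(Cc2cn3cc(OCC4CC4)c(Cl)cc3n2)c2ccccc2c1=O`) gives 12 mL/min/kg, within the scatter of compound 2 (`O=C(O)Cc1nn(Cc2cn3cc(OCC4CC4)c(Cl)cc3n2)c2ccccc2c1=O`) at 11.7 mL/min/kg. Compound 1 (`O=C(O)Cn1nc(Cc2cn3cc(OCC4CC4)c(Cl)cc3n2)c2ccccc2c1=O`), at 4.83 mL/min/kg, lies lower than compound 3, beyond the scatter. Compound 4 (`C[C@H](C(=O)O)c1nn(Cc2cn3cc(OCC4CC4)c(Cl)cc3n2)c2ccccc2c1=O`) carries 1-carboxyethyl in place of 1-carboxypropyl on an aromatic carbon. Among the measured compounds shown here, the one measured step at this carbon, a 1.0-fold higher number from compound 2 to compound 3 (0.01 log units; within the scatter), replaced hydrogen with ethyl and stayed within the scatter. For the measured compounds named here, no measured pair tests the defined stereocentre. A change beyond the scatter is therefore not expected, and the expected shift is a 1.1-fold lower number from compound 3 to compound 4 (0.04 log units; within the scatter). For compound 4 the estimated clearance is 11 mL/min/kg, with an expected range of 5.5 mL/min/kg to 22 mL/min/kg.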

Compound 4, clearance in the Mus musculus assay: 7.83 mL/min/kg
Compound 4: the middle estimate sits 1.4-fold (0.15 log units) above what was measured; measured number inside the range.
By their numbers in the Mus musculus assay, from the lowest: compounds 1, 4, 2 and 3 (each within the scatter of the next, the first and the last beyond it).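

In the Mus musculus assay, the steps of a 1.5-fold lower number from compound 3 to compound 4 (0.19 log units; within the scatter) and a 1.5-fold lower number from compound 2 to compound 4 (0.17 log units; within the scatter) join the earlier ethyl step, so hydrogen, methyl and ethyl on this saturated chain carbon are not told apart by clearance. Among the compounds shown here, the same change does register in a physicochemical assay for solubility, measured as thermodynamic solubility, at pH 7.4 (a higher number here means a more soluble compound, a lower number a less soluble compound), which the earlier compounds did not show: the measured solubility of compound 3, 359 ug/mL, and of compound 4, 892 ug/mL, a 2.5-fold higher number (0.40 log units; beyond the scatter). In the physicochemical assay compound 3 gives 359 ug/mL and compound 4 gives 892 ug/mL.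

From the compounds shown here alone, whether the defined stereocentre of compound 4 contributes to either number remains open. So does the question of how a longer chain or an amine on this carbon would affect clearance and solubility.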